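The compounds below may be only part of what the source reports. "The series", "measured", "known", "first", "only" and "open" are said of these compounds alone.

In a functional assay on CWR22R cells (Homo sapiens) for inhibition, with a stated time of 120 h, tested at 10 uM (a lower number here means less inhibition, a higher number more inhibition at the concentration tested (going by the name of the read-out)), compound 1 `Cc1n[nH]c2ccc(-c3nc4cnc(N5CCN(C)CC5)cn4c3Nc3cccc(F)c3)cc12` gives 5.41%, a weak reading. Compound 2 `Cc1n[nH]c2ccc(-c3nc4cnc(N5CCN(C)CC5)cn4c3Nc3ccccc3Cl)cc12` and compound 3 `Cc1ccc(C)c(Nc2c(-c3ccc4[nH]nc(C)c4c3)nc3cnc(N4CCN(C)CC4)cn23)c1` share the core of compound 1 but carry a different group on the nitrogen on an aromatic ring. In this assay compound 2 gives "not determined" (no result reported), and in this assay compound 3 gives "not determined" (no result reported); compound 3 therefore stands without a number, and so does compound 2. Compound 4 `Cc1n[nH]c2ccc(-c3nc4cnc(N5CCN(C)CC5)cn4c3Nc3ccc(F)c(Cl)c3)cc12` has not yet been tested. It differs from compound 3 in one place: 3-chloro-4-fluorophenyl in place of 2,5-dimethylphenyl on a nitrogen on an aromatic ring. For the measured compounds named here, as no measured step leads from compound 3 to compound 4, nothing can be said about the size or direction of this change, and compound 1 is the only anchor. Because compound 1 gives 5.41%, compound 4 is expected to show a similarly low figure of 8%, in a range from 0% to 25%.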

Compound 4, a percentage reported as inhibition, at one concentration (the size of the read-out at that concentration, not a potency): 0.82%
Compound 4: the middle estimate sits 7.2 percentage points above what was measured; measured number inside the range.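

In this assay, 3-chloro-4-fluorophenyl in place of 3-fluorophenyl on a nitrogen on an aromatic ring gives a number 4.6 percentage points lower from compound 1 to compound 4 (within the scatter), so adding the chlorine and moving the fluorine produce no readable difference at this position. With compound 3 lacking a number, the step from 2,5-dimethylphenyl cannot be read. Nothing measured here accounts for the result.

The compounds shown leave open whether a phenyl ring carrying an amine or a carboxylic acid, or a cyclohexyl group on this nitrogen, would read any differently. They also leave open whether any change at this position lifts the reading.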